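Methyl to Oxazolyl on the Amine: Cytotoxicity Outlook

The source may report more compounds than this note shows. Statements on the series, on what has been measured and on what is new or still open speak of the compounds shown alone.

Compound 1 `Nc1nc(Cl)c(-c2ccccn2)c(N[C@@H]2C[C@H](CO)[C@@H](O)[C@H]2O)n1` was examined in an ADME assay on cells (Homo sapiens) for cytotoxicity, read by polymerase chain reaction, with a stated time of 3 days; on this read-out lower numbers stand for higher toxicity in this test and higher numbers for lower toxicity in this test. In this assay compound 1 gives > 25000 nM, which is a limit of the assay and not a number. Compound 2 `Nc1nc(Cl)c(-c2cc3ccccc3s2)c(N[C@@H]2C[C@H](CO)[C@@H](O)[C@H]2O)n1` carries 1-benzothiophen-2-yl in place of pyridin-2-yl on an aromatic carbon; in this assay compound 2 gives > 25000 nM, again a limit of the assay. The step that the two limits leave unreadable from compound 1 to compound 2 is thus unreadable. Compound 3 `CNc1nc(C)c(-c2nc3ccccc3s2)c(N[C@@H]2C[C@H](CO)[C@@H](O)[C@H]2O)n1` stands where the other two stand: in this assay compound 3 gives > 25000 nM, a limit of the assay rather than a number. Every value shown sits at the limit of > 25000 nM in this assay, at which 3 of the 3 values shown sit.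

Compound 4 `Cc1nc(Nc2ncco2)nc(N[C@@H]2C[C@H](CO)[C@@H](O)[C@H]2O)c1-c1nc2ccccc2s1` differs from compound 3 in one place: 1,3-oxazol-2-yl in place of methyl on a nitrogen on an aromatic ring. Within the data shown here, no measured step touches this nitrogen, and the one measured step, from compound 1 to compound 2, lies between two limits and carries no size over. Because every value shown sits at the limit of > 25000 nM in this assay, at which 3 of the 3 values shown sit, compound 4 is expected to remain at the limit as well, with no step beyond the scatter. The step of a number no higher from compound 3 to compound 4 (the limit leaves the size open) is accordingly expected to be close to nothing. For compound 4 the estimate in this assay is 25000 nM, between 10000 nM and 60000 nM.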

Compound 4, half-maximal cytotoxic concentration: > 25000 nM
Compound 4: no number, only a limit; the forecaster's own chance of this, stated with the estimate: 85%; the middle value sits exactly at the limit.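

In this assay compound 4 gives > 25000 nM, a limit of the assay and not a number. Compound 3 also stands at a limit, and the step between compound 3 and compound 4 cannot be read. The compounds shown leave open whether methyl and 1,3-oxazol-2-yl on this nitrogen differ at all in cytotoxicity, and how much toxicity any compound has, with all the data resting on one point: the limit of > 25000 nM in this assay, at which 4 of the 4 values shown sit.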